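The source may report more compounds than this note shows. Statements on the series, on what has been measured and on what is new or still open speak of the compounds shown alone.

In a functional assay on SEM cells (Homo sapiens) for cytotoxicity, with a stated time of 72 h (on this read-out lower numbers stand for an effect already at smaller amounts and higher numbers for an effect only at larger amounts of compound), compound 1 `C=C[C@@](C)(/C=C/c1ccc(OCc2ccccc2)cc1)CCC=C(C)C` gives > 36600 nM as a limit, not a number. Compound 2 `C=C[C@@](C)(/C=C/c1ccc(Nc2ccc(F)cc2)cc1)CCC=C(C)C` gives > 36600 nM as a limit too. Compound 3 `C=C[C@@](C)(/C=C/c1ccc(Nc2cc(F)c(F)c(F)c2)cc1)CCC=C(C)C` also gives only a limit, > 36600 nM, so its true standing is not known. Compound 4 `C=C[C@@](C)(/C=C/c1ccc(Nc2ccc(Cl)c(Cl)c2)cc1)CCC=C(C)C` carries 3,4-dichlorophenyl in place of 3,4,5-trifluorophenyl on a nitrogen on an aromatic ring. The closest guide is a step that the two limits leave unreadable from compound 2 to compound 3, a change at the same place, and the other is a step that the two limits leave unreadable from compound 1 to compound 2. Among the compounds with values here, neither has a readable size, and the series so far rests on (the limit of > 36600 nM in this assay, at which 3 of the 3 values shown sit), so no change beyond the scatter is expected in this assay, in either direction. The step is expected to be small (a number no higher from compound 3 to compound 4 (the limit leaves the size open)). Compound 4 is expected near 36600 nM (estimated range 12000 nM to 80000 nM).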

Compound 4, half-maximal effective concentration: > 36600 nM
Compound 4: only a limit was reported; the forecaster's own chance of this, stated with the estimate: 70%; the middle value sits exactly at the limit.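

Compound 4, like compound 1, compound 2 and compound 3, gives only a limit in this assay, so no step among them can be read: the limit of > 36600 nM in this assay, at which 4 of the 4 values shown sit.

The compounds shown leave open where the true values of these four compounds lie and how they compare with one another.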